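The compounds below may be only part of what the source reports. "The series", "measured", "known", "first", "only" and "open" are said of these compounds alone.

Working notes on the shared core of compound 1 `COc1nc2ccccc2cc1/C=C/c1noc(-c2ccc(C)cc2)n1`, compound 2 `COc1ccc(-c2nc(/C=C/c3cc4ccccc4nc3OC)no2)cc1` and compound 3 `COc1nc2ccccc2cc1/C=C/c1noc(-c2cccc(C)c2)n1`, all read in an ADME assay on HepG2 cells (Homo sapiens) for cytotoxicity, read by sulforhodamine B assay, with a stated time of 48 h; on this read-out higher numbers stand for lower toxicity in this test and lower numbers for higher toxicity in this test. Compound 1 reaches only a limit of the assay, > 230000 nM. Compound 2 likewise gives a limit, > 220000 nM. Compound 3 also ends at a limit, > 230000 nM. The whole set so far sits at limits, namely the limit of > 220000 nM in this assay, at which 1 of the 3 values shown sits, and (the limit of > 230000 nM in this assay, at which 2 of the 3 values shown sit). The steps a step that the two limits leave unreadable from compound 1 to compound 2, a step that the two limits leave unreadable from compound 1 to compound 3 and a step that the two limits leave unreadable from compound 2 to compound 3 therefore carry no readable size in this assay, and compound 3 stands where the other two stand: at a limit, not at a number.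

Compound 4 `COc1nc2ccccc2cc1/C=C/c1noc(-c2ccco2)n1` differs from compound 3 by furan-2-yl in place of 3-methylphenyl on an aromatic carbon. Of the measured steps none bears a size: methoxy in place of methyl, 3-methylphenyl in place of 4-methylphenyl and 3-methylphenyl in place of 4-methoxyphenyl all run from limit to limit. No magnitude can be carried over to the step from compound 3 to compound 4, and with nothing in this assay pointing either way the default expectation is no step beyond the scatter. The estimate for compound 4 is 230000 nM, within 90000 nM to 500000 nM, which means an expected step of a number no higher from compound 3 to compound 4 (the limit leaves the size open).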

Compound 4, half-maximal cytotoxic concentration: > 250000 nM
Compound 4: only a limit was reported; the forecaster's own chance of this, stated with the estimate: 70%; middle value at least 1.0-fold (0.03 log units) from the limit.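

Compound 4, like compound 1, compound 2 and compound 3, gives only a limit in this assay, and none of its steps to those three can be read. The compounds shown leave open how large any step between these groups is, and at what concentration any of the four would show toxicity in this test.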